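This account rests on a few compounds, and the source may have more. Where it says the series, first, only, none or still open, it means among the compounds named here.

Measured so far:
Compound 1, `CN(C)CCN(C)c1cc(-c2cn[nH]c2)ccc1NC(=O)NCc1ccccc1`: in an assay on isolated protein for inhibition of Rho-associated protein kinase 2 (Homo sapiens), read by HTRF, with a stated time of 4 h (on this read-out higher numbers stand for weaker inhibition and lower numbers for stronger inhibition), compound 1 gives 8.5 nM.
Compound 2, `COc1cccc(CNC(=O)Nc2ccc(-c3cn[nH]c3)cc2F)c1`: in this assay compound 2 gives < 1 nM, which is a limit of the assay and not a number.

Compound 2 thus stands at the limit of < 1 nM in this assay, at which 1 of the 2 values shown sits, so only an upper bound is known for it. Compound 3, `COc1cccc(CNC(=O)Nc2ccc(-c3cn[nH]c3)cc2N(C)CCN(C)C)c1`, is not yet measured. It differs from compound 2 in one place: (2-(dimethylamino)ethyl)(methyl)amino in place of fluoro on an aromatic carbon. The same side chain is already present in compound 1, which differs from compound 3 only in lacking the methoxy group on the benzyl part, and compound 1 sits above the limit. Within the data shown here, no measured pair isolates this particular change, so its size can only be guessed. For compound 3 the expected step is an at least 3.0-fold higher number from compound 2 to compound 3 (0.47 log units; beyond the scatter), a modest weakening that may or may not exceed the scatter. Compound 3 is therefore estimated at 3 nM, with a likely range from 0.8 nM to 12 nM.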

Compound 3, half-maximal inhibitory concentration: < 1 nM
Compound 3 ended at the assay's limit (the forecaster's own chance of this, stated with the estimate: 25%); at least 3.0-fold (0.47 log units) between middle value and limit.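

In this assay compound 3 gives < 1 nM, which is a limit of the assay and not a number. This aromatic carbon therefore takes the (2-(dimethylamino)ethyl)(methyl)amino chain in place of fluoro with no loss this assay can detect, but the size of that change cannot be read, because both compounds sit at the limit: the limit of < 1 nM in this assay, at which 2 of the 3 values shown sit.

With the chain held constant, methoxy in place of hydrogen on an aromatic carbon of the benzyl part gives an at least 8.5-fold lower number from compound 1 to compound 3 (0.92 log units; beyond the scatter), so this small group clearly matters in this series.

On these data alone, how far compound 2 and compound 3 lie past the limit remains unknown, so fluoro and the chain cannot be ranked. Also open, as far as these compounds go, is whether a carboxylic acid or a shorter amine chain at this position would keep the inhibition.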